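Ring size at the amine: from azetidine to azepane

The source may hold more compounds than are shown below. What is called first, only, known or untested is meant among the compounds shown, and "the series" means these compounds.

Measured compounds:
- compound 1, `Cc1nn([C@H](C)c2ccc(Cl)cc2Cl)c2nc(N3CC[C@H](N4CCCC4)[C@H](C)C3)cnc12`: "not determined" (no result reported) in an assay on CCRF-CEM cells for antagonist activity at C-C chemokine receptor type 4 (Homo sapiens), read by CellTiter-Glo, with stated times of 30 min and 60 min, in the presence of a further agent that is not named here; a higher number here means a weaker inhibitor, a lower number a stronger inhibitor
- compound 2, `Cc1nn([C@H](C)c2ccc(Cl)cc2Cl)c2nc(N3CC[C@H](N4CCC4)[C@H](C)C3)cnc12`: 218 nM
- compound 3, `C[C@@H]1CC(c2cnc3c(C#N)nn([C@H](C)c4ccc(Cl)cc4Cl)c3n2)=CC[C@@H]1N1CCC[C@H]1CO`: 70 nM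

Within the data shown here, only two numbers are known. Compound 2 has the higher of the two, and its nearest neighbour is compound 3, whose number is lower by an amount beyond the usual scatter, so compound 3 is the stronger inhibitor of the pair. Compound 1 carries no value, so it cannot be placed.

Compound 4, `Cc1nn([C@H](C)c2ccc(Cl)cc2Cl)c2nc(N3CC[C@H](N4CCCCCC4)[C@H](C)C3)cnc12`, is compound 2 with one change: azepan-1-yl in place of azetidin-1-yl on a saturated ring carbon, in words azepan-1-yl in place of azetidin-1-yl on a saturated ring carbon. Among the measured compounds shown here, no measured pair shows this change, and compound 1, which carries a ring of intermediate size there, has no number to guide the direction. The step from compound 2 to compound 4 in this assay is therefore expected to be small, a 1.4-fold higher number from compound 2 to compound 4 (0.14 log units; within the scatter), without a clear direction beyond the scatter. For compound 4 the expected value is 300 nM, within a range from 90 nM to 1000 nM.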

Compound 4, half-maximal inhibitory concentration: 195 nM
Beside the measured number, compound 4's estimate is 1.5-fold (0.19 log units) above it, within the range that was stated.
By their numbers in this assay, from the lowest: compound 3; then compounds 4 and 2 (each within the scatter of the next).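

Among these compounds, this is the first pair that differs only in the amine ring, and it gives a direct reading of ring size at this position. In this assay, replacing azetidin-1-yl with the much larger azepan-1-yl gives a 1.1-fold lower number from compound 2 to compound 4 (0.05 log units; within the scatter), so the two compounds cannot be told apart, even though the ring grows from four members to seven. Nothing available explains why the number stays within the scatter.

Going by these compounds, compound 1 carries no number, so steps involving it cannot be read, and the behaviour of the ring of intermediate size remains unknown. Also open, on these data alone, is whether this insensitivity extends to amines of another kind, such as morpholin-4-yl, with an oxygen in the ring, or an open-chain dimethylamino group.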